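Ester in place of the aminoamino group on the shared core

The source may report more compounds than this note shows. Statements on the series, on what has been measured and on what is new or still open speak of the compounds shown alone.

The series shares one core, seen in compound 1 `CC(=O)c1ccc(NC(=O)c2nc(-c3ccccc3)n(-c3ccc(S(N)(=O)=O)cc3)n2)cc1`, compound 2 `NS(=O)(=O)c1ccc(-n2nc(C(=O)NC3CCCCC3)nc2-c2ccccc2)cc1` and compound 3 `NNC(=O)c1nc(-c2ccccc2)n(-c2ccc(S(N)(=O)=O)cc2)n1`, and differs only in what sits on the carbonyl carbon. In a functional assay on the whole organism for inhibition, with Rattus norvegicus as the target, read by paw edema, with stated times of 30 min and 4 h, at a dose of 0.28 mmol/kg by the oral route (a higher number here means more inhibition at the dose given (going by the name of the read-out), a lower number less inhibition), compound 1 gives 64%, compound 2 gives 53% and compound 3 gives 45%. Compound 3 stands lowest of the three numbers: its nearest neighbour is compound 2, within the scatter, and its furthest is compound 1, beyond the scatter. The two steps that reach beyond the scatter are a number 11 percentage points lower from compound 1 to compound 2 (beyond the scatter) and a number 19 percentage points lower from compound 1 to compound 3 (beyond the scatter), while a number 8 percentage points lower from compound 2 to compound 3 (within the scatter) stays within it.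

Compound 4 `COC(=O)c1nc(-c2ccccc2)n(-c2ccc(S(N)(=O)=O)cc2)n1` is not yet measured. Its difference from compound 3 is methoxy in place of aminoamino on a carbonyl carbon. Going by the values given here, no measured step changes the carbonyl substituent in this way; all three steps exchange groups on an amide-type nitrogen, and the 4-acetylphenyl group that gave the highest number is absent from both compound 3 and compound 4. The bearing of the measured steps is therefore indirect. The expected step is estimated as a number 3 percentage points lower from compound 3 to compound 4 (within the scatter). For compound 4 the value is estimated at 42%, in the range 28% to 58%.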

Compound 4, a percentage reported as inhibition, in the whole organism at one dose (the size of the read-out at that dose, not a potency): 61%
The estimate for compound 4 lay 19 percentage points below the measured number; the measured number lies above the stated range.
By their numbers in this assay, from the lowest: compounds 3, 2, 4 and 1 (each within the scatter of the next, the first and the last beyond it).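

In this assay the change made on the carbonyl carbon itself, methoxy in place of aminoamino, gives a number 16 percentage points higher from compound 3 to compound 4 (beyond the scatter), so at this position the outcome also depends on a replacement that removes the amide-type nitrogen altogether, which the steps among the amides could not show. Measured against the two larger amides, the same position gives a number 8 percentage points higher from compound 2 to compound 4 (within the scatter) and a number 3 percentage points lower from compound 1 to compound 4 (within the scatter), so in these compounds neither the amide-type nitrogen nor the cyclohexyl or 4-acetylphenyl group on it is required for a number at this level, and methoxy cannot be told apart from either group in this read-out. No measurement at hand accounts for the step from aminoamino to methoxy.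

Going by these compounds, whether a carboxylic acid, or an ethyl or longer chain on the ester oxygen, would hold the number at this level stays open, and so does whether the plain primary amide would sit with compound 3 or with compound 4. The read-out is also a single oral dose, so it leaves the relative potency of these compounds undecided.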